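This account rests on a few compounds, and the source may have more. Where it says the series, first, only, none or still open, it means among the compounds named here.

Measured compounds in a functional assay on U-87MG ATCC cells for antiproliferative activity against U-87 MG (Homo sapiens), read by MTT assay, with a stated time of 72 h; on this read-out lower numbers stand for stronger inhibition and higher numbers for weaker inhibition:
compound 1, `CCNC(=O)c1cc(Oc2ccc(NC(=O)c3cc4cccnc4n(-c4ccccc4)c3=O)cc2)ccn1`: 2650 nM
compound 2, `CCNC(=O)c1cc(Oc2ccc(NC(=O)c3cc4cccnc4n(-c4ccccc4F)c3=O)cc2)ccn1`: 3250 nM
compound 3, `CCNC(=O)c1cc(Oc2ccc(NC(=O)c3cc4cccnc4n(-c4ccc(Br)cc4F)c3=O)cc2)ccn1`: 10300 nM

Compound 2 holds the second highest of the three numbers. Its nearest neighbour is compound 1, with a 1.2-fold higher number from compound 1 to compound 2 (0.09 log units; within the scatter), a step that does not leave the usual scatter. Its furthest neighbour is compound 3, with a 3.2-fold higher number from compound 2 to compound 3 (0.50 log units; beyond the scatter); from compound 1 the corresponding step is a 3.9-fold higher number from compound 1 to compound 3 (0.59 log units; beyond the scatter). All three measured steps change the phenyl that sits on the aromatic nitrogen of the shared core.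

Compound 4, `CCCNC(=O)c1cc(Oc2ccc(NC(=O)c3cc4cccnc4n(-c4ccccc4F)c3=O)cc2)ccn1`, differs from compound 2 in a different place: methyl in place of hydrogen on a saturated chain carbon, two bonds along the chain from an amide-type nitrogen. Among the measured compounds shown here, none of the measured steps touches the amide chain, so nothing measured bears directly on this change. With no evidence either way, the step in this assay is expected to stay within the scatter, and the direction is left open.

For compound 4 the estimated step from compound 2 is a 1.1-fold higher number from compound 2 to compound 4 (0.03 log units; within the scatter). The expected value for compound 4 is 3500 nM, with a range from 1600 nM to 7500 nM.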

Compound 4, half-maximal inhibitory concentration: 2320 nM
Compound 4: the middle estimate sits 1.5-fold (0.18 log units) above what was measured; the measured number falls inside the stated range.
By their numbers in this assay, from the lowest: compounds 4, 1 and 2 (each within the scatter of the next); then compound 3.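

Among the compounds shown here, compound 4 gives the first reading on the amide chain, which none of the earlier steps touched: in this assay, ethyl to propyl, with methyl in place of hydrogen on a saturated chain carbon, two bonds along the chain from an amide-type nitrogen, gives a 1.4-fold lower number from compound 2 to compound 4 (0.15 log units; within the scatter), so compounds 2 and 4 cannot be told apart on this read-out. From the same compound, the bromo step on the aromatic carbon gives a 3.2-fold higher number from compound 2 to compound 3 (0.50 log units; beyond the scatter), so this single comparison shows a chain change that stays inside the scatter, while that change on the phenyl goes beyond it. Nothing at hand explains the outcome of the chain change.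

The compounds shown leave open whether a longer chain such as butyl, a branched chain such as isopropyl, or a chain ending in an amine or a carboxylic acid would also stay within the scatter. They also leave open whether ethyl to propyl reads the same way with the phenyl of compound 1 or the 4-bromo-2-fluorophenyl of compound 3 on the aromatic nitrogen.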